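The source may report more compounds than this note shows. Statements on the series, on what has been measured and on what is new or still open speak of the compounds shown alone.

In a physicochemical assay for solubility, in phosphate buffer, at pH 7.4 (a lower number here means a less soluble compound, a higher number a more soluble compound), compound 1 `CC(=O)N[C@@H]1CCC[C@H](C(=O)Nc2cc(-c3cnc4n3CCCC4)c(Cl)cn2)C1` gives 600000 nM, and compound 2 `CC(=O)N[C@@H]1CCC[C@H](C(=O)Nc2cc(-c3cnn4c3CCC4)c(Cl)cn2)C1` gives 160000 nM, the lower of the two numbers. Compound 3 `CC(=O)N[C@@H]1CCC[C@H](C(=O)Nc2cc(-c3cnn4c3CCCCC4)c(Cl)cn2)C1` has not yet been measured. Its difference from compound 2 is a group of 10 heavy atoms (8 carbon, 2 nitrogen; one five-membered aromatic ring with 2 hetero atoms, one seven-membered non-aromatic ring with 1 hetero atom) in place of a group of 8 heavy atoms (6 carbon, 2 nitrogen; one five-membered non-aromatic ring with 1 hetero atom, one five-membered aromatic ring with 2 hetero atoms), on an aromatic carbon: a group with one seven-membered non-aromatic ring takes the place of a group with one five-membered non-aromatic ring, on an aromatic carbon, ortho to a chloro group. For the measured compounds named here, only one measured step bears on this change: a 3.8-fold lower number from compound 1 to compound 2 (0.57 log units; beyond the scatter), in which a group with a five-membered non-aromatic ring replaced one with a six-membered non-aromatic ring. Read in reverse, that modest step hints that the larger group in compound 3 could give a higher number in this assay. However, no compound with a seven-membered non-aromatic ring has been measured, and a single step establishes no trend. Only a slight rise is therefore expected, and a 1.3-fold higher number from compound 2 to compound 3 (0.10 log units; within the scatter) is estimated to stay within the scatter. For compound 3 the expected solubility is 200000 nM, with an estimated range of 70000 nM to 550000 nM.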

Compound 3, solubility: 104000 nM
Beside the measured number, compound 3's estimate is 1.9-fold (0.28 log units) above it; low and high end bracket the measured number.
By their numbers in this assay, from the lowest: compounds 3 and 2 (each within the scatter of the next); then compound 1.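

In this assay, going from the five-membered to the seven-membered non-aromatic ring, on this aromatic carbon ortho to a chloro group, gives a 1.5-fold lower number from compound 2 to compound 3 (0.19 log units; within the scatter), so the two larger-gap ring sizes cannot be told apart here. Going from the six-membered to the seven-membered ring gives a 5.8-fold lower number from compound 1 to compound 3 (0.76 log units; beyond the scatter), which, together with a 3.8-fold lower number from compound 1 to compound 2 (0.57 log units; beyond the scatter), leaves compound 1 apart from both of the others, and the number does not rise steadily with ring size: the reading of the first step as a gain from a larger group fails at compound 3, which goes against it. No measurement at hand speaks to why the three groups fall as they do.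

The compounds shown leave open whether the number of compound 1 belongs to its six-membered ring or to some other feature of its group, since only three groups have been compared at this position. They also leave open what an amine or a carboxylic acid on the non-aromatic ring, or an oxygen atom within that ring, would do to the number.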